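The compounds below may be only part of what the source reports. "The series", "measured", "known", "first", "only" and "open" are said of these compounds alone.

In a toxicity assay on CCRF-CEM cells (Homo sapiens) for cytotoxicity (on this read-out higher numbers stand for lower toxicity in this test and lower numbers for higher toxicity in this test), compound 1 `COC(=O)c1cccc2c1nc(-c1c(F)cccc1F)n2Cc1c(F)cccc1F` gives 57.7 uM and compound 2 `CC(=O)Nc1cccc2c1nc(-c1c(F)cccc1F)n2Cc1c(F)cccc1F` gives 39.3 uM, so compound 2 stands within the scatter of compound 1. The next molecule is compound 3 `CN(C)c1cccc2c1nc(-c1c(F)cccc1F)n2Cc1c(F)cccc1F`, which carries dimethylamino in place of acetamido on an aromatic carbon. Going by the values given here, the one measured step at this aromatic carbon, a 1.5-fold lower number from compound 1 to compound 2 (0.17 log units; within the scatter), stayed within the scatter, although it exchanged a different pair of groups. No step beyond the scatter is therefore expected, and the estimated step is a 1.1-fold higher number from compound 2 to compound 3 (0.06 log units; within the scatter). For compound 3 the expected value is 45 uM, with an estimated range of 18 uM to 100 uM.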

Compound 3, half-maximal toxic concentration: > 100 uM
Compound 3 was reported as a limit (the forecaster's own chance of this, stated with the estimate: 15%); at least 2.2-fold (0.34 log units) between middle value and limit.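

The value of compound 3 is a limit of the assay, not a number: the limit of > 100 uM in this assay, at which 1 of the 3 values shown sits. Even so, dimethylamino in place of acetamido on this aromatic carbon gives the one step here that lies beyond the scatter, an at least 2.5-fold higher number from compound 2 to compound 3 (0.40 log units; beyond the scatter), so the read-out in this assay does respond to the group at this position. Against methoxycarbonyl the floor is smaller, an at least 1.7-fold higher number from compound 1 to compound 3 (0.23 log units; that floor lies within the scatter), and this comparison stays undecided.

Going by these compounds, whether a primary amine or a methylamino group on this carbon would behave like dimethylamino remains open. On these data alone, the true value of compound 3 also remains open.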